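From Bromophenyl to Trifluoromethylphenyl: an Expected Cellular Read-out

The compounds below may be only part of what the source reports. "The series", "measured", "known", "first", "only" and "open" are said of these compounds alone.

Of the compounds shown here, three built on one shared core have been tested in a functional assay on NCI-H1975 cells (Homo sapiens) for inhibition, read by MTT assay, with a stated time of 72 h; on this read-out lower numbers stand for stronger inhibition and higher numbers for weaker inhibition. Compound 1 `C=CC(=O)Nc1cccc(NC(=O)CSc2nc(Nc3ccccc3)c3ccccc3n2)c1` gives 8120 nM. Compound 2 `C=CC(=O)Nc1cccc(NC(=O)CSc2nc(Nc3ccccc3C)c3ccccc3n2)c1` gives 9920 nM, and compound 3 `C=CC(=O)Nc1cccc(NC(=O)CSc2nc(Nc3cccc(Br)c3)c3ccccc3n2)c1` gives 12100 nM. Compound 3 carries the highest of the three numbers, yet its distances to the others are small: a 1.5-fold higher number from compound 1 to compound 3 (0.17 log units; within the scatter) and a 1.2-fold higher number from compound 2 to compound 3 (0.09 log units; within the scatter), both within the scatter, so no ranking among the three can be claimed.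

Compound 4 `C=CC(=O)Nc1cccc(NC(=O)CSc2nc(Nc3ccc(C(F)(F)F)cc3)c3ccccc3n2)c1` has not yet been measured. It differs from compound 3 in one place: 4-(trifluoromethyl)phenyl in place of 3-bromophenyl on a nitrogen on an aromatic ring. The measured steps that bear on this change are those that alter the same ring on the same nitrogen: a 1.2-fold higher number from compound 1 to compound 2 (0.09 log units; within the scatter), a 1.5-fold higher number from compound 1 to compound 3 (0.17 log units; within the scatter) and a 1.2-fold higher number from compound 2 to compound 3 (0.09 log units; within the scatter). None of them moved the read-out beyond the scatter, and nothing in the series shows a trifluoromethyl group at all. On that basis the step of a 1.2-fold lower number from compound 3 to compound 4 (0.08 log units; within the scatter) is expected to remain within the scatter, with no direction favoured. Compound 4 is therefore estimated at 10000 nM, with a range from 4000 nM to 25000 nM.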

Compound 4, half-maximal inhibitory concentration: 12900 nM
Beside the measured number, compound 4's estimate is 1.3-fold (0.11 log units) below it; the range from low to high includes it.
By their numbers in this assay, from the lowest: compounds 1, 2, 3 and 4 (each within the scatter of the next).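

For the compounds shown here, the trifluoromethyl group, which none of the earlier compounds carries, enters the series in this assay without taking the read-out beyond the scatter, whether compound 4 is set against the bromo, methyl or unsubstituted ring (in turn a 1.1-fold higher number from compound 3 to compound 4 (0.03 log units; within the scatter) then a 1.3-fold higher number from compound 2 to compound 4 (0.11 log units; within the scatter) and finally a 1.6-fold higher number from compound 1 to compound 4 (0.20 log units; within the scatter)). The exchange also replaces 3-bromophenyl, of 7 heavy atoms, with 4-(trifluoromethyl)phenyl, of 10 heavy atoms, so the place on the nitrogen on an aromatic ring has now held four different aromatic groups, and all four compounds stand within the scatter of one another. Nothing available here accounts for this flat picture or says what lies behind the read-out in these cells.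

What the compounds shown leave open is whether the read-out at this nitrogen can leave the scatter at all, since each group tested so far keeps an aromatic carbon ring with no hydrogen-bond donors or acceptors. A carboxylic acid or an amine on that ring, or a morpholine ring or a longer chain in its place, would put that question to the test.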